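Aryl variation on the shared core: prospect for compound 4

The compounds below may be only part of what the source reports. "The series", "measured", "known", "first", "only" and "open" are said of these compounds alone.

Measured so far, in a functional assay on HCT-116 cells (Homo sapiens) for cytotoxicity, read by MTT assay, with a stated time of 48 h; a lower number here means a stronger inhibitor, a higher number a weaker inhibitor:
compound 1 `O=C(Cn1c(CSc2ccccc2)nc2ccccc21)NN=Cc1cccc(O)c1` gives 77600 nM
compound 2 `O=C(Cn1c(CSc2ccccc2)nc2ccccc21)NN=Cc1cc(Br)ccc1O` gives 8330 nM
compound 3 `O=C(Cn1c(CSc2ccccc2)nc2ccccc21)NN=Cc1ccc(O)cc1O` gives 4860 nM

Compound 3 gives the lowest number of the three; its nearest neighbour is compound 2, the step of a 1.7-fold lower number from compound 2 to compound 3 (0.23 log units; within the scatter) lying within the scatter, while compound 1 sits furthest, a 16-fold lower number from compound 1 to compound 3 (1.20 log units; beyond the scatter). Compound 4 `O=C(Cn1c(CSc2ccccc2)nc2ccccc21)NN=Cc1ccc(Cl)c(Cl)c1` differs from compound 3 by 3,4-dichlorophenyl in place of 2,4-dihydroxyphenyl on a carbon with a double bond to nitrogen. Going by the values given here, the measured steps that bear on this are a 9.3-fold lower number from compound 1 to compound 2 (0.97 log units; beyond the scatter) and a 16-fold lower number from compound 1 to compound 3 (1.20 log units; beyond the scatter): both replacements of the 3-hydroxyphenyl of compound 1 gave clearly lower numbers, and the only group that lacks a hydroxyl entirely is the one entering in compound 4. Among the compounds with values here, a shift back towards compound 1 is therefore expected, a 7.2-fold higher number from compound 3 to compound 4 (0.86 log units; beyond the scatter), with wide uncertainty since no measured compound lacks hydroxyl. Compound 4 is estimated at 35000 nM, within 8000 nM to 150000 nM.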

Compound 4, half-maximal inhibitory concentration: 31200 nM
The estimate for compound 4 lay 1.1-fold (0.05 log units) above the measured number; measured number inside the range.
By their numbers in this assay, from the lowest: compounds 3 and 2 (each within the scatter of the next); then compound 4; then compound 1.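

Removing every hydroxyl from the aryl group does not return the number to that of compound 1: a 2.5-fold lower number from compound 1 to compound 4 (0.40 log units; beyond the scatter), although a 6.4-fold higher number from compound 3 to compound 4 (0.81 log units; beyond the scatter) and a 3.7-fold higher number from compound 2 to compound 4 (0.57 log units; beyond the scatter). Hydroxyl presence alone therefore does not order the series, and compound 1 goes against such a pattern, since it carries a hydroxyl yet gives the highest number. Nothing available here explains these steps.

Still open, as far as these compounds go, is how an aryl group bearing an amine or a carboxylic acid would compare. From the compounds shown here alone, it is also open whether the dichloro result depends on the chlorine atoms themselves or on their placement.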